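Swapping the aryl substituent on a shared amide core

This account rests on a few compounds, and the source may have more. Where it says the series, first, only, none or still open, it means among the compounds named here.

Measured so far:
compound 1, `O=C(Nc1ccc(Oc2ccnc3[nH]ccc23)c(F)c1)c1cc(-c2ccccc2)ccn1`, 4950 nM
compound 2, `Cc1cccc(-c2ccnc(C(=O)Nc3ccc(Oc4ccnc5[nH]ccc45)c(F)c3)c2)c1`, 1750 nM
compound 3, `Cc1ccc(-c2ccnc(C(=O)Nc3ccc(Oc4ccnc5[nH]ccc45)c(F)c3)c2)c(C)c1`, 4350 nM

Three compounds share one core and differ only in the aryl group carried on the pyridine ring. In a functional assay on A549 cells (Homo sapiens) for cytotoxicity, read by MTT assay, with a stated time of 72 h (a higher number here means a weaker inhibitor, a lower number a stronger inhibitor), compound 1 gives 4950 nM. Compound 2 gives 1750 nM, and the change is a 2.8-fold lower number from compound 1 to compound 2 (0.45 log units; beyond the scatter). Compound 3 gives 4350 nM; from the parent the step is a 1.1-fold lower number from compound 1 to compound 3 (0.06 log units; within the scatter), while against compound 2 it is a 2.5-fold higher number from compound 2 to compound 3 (0.40 log units; beyond the scatter). Compound 3 thus stands second highest of the three numbers, and its separation from compound 1 is inside the scatter.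

Compound 4, `CCc1ccc(-c2ccnc(C(=O)Nc3ccc(Oc4ccnc5[nH]ccc45)c(F)c3)c2)cc1`, differs from compound 3 by 4-ethylphenyl in place of 2,4-dimethylphenyl on an aromatic carbon. Going by the values given here, none of the measured steps sets an ethyl group on that ring, so the closest guides are the small moves already seen: one methyl gave a modest drop, a second methyl undid it. A single substituent at the position of the 4-ethylphenyl group has no measured parallel, so the expected step of a 1.2-fold lower number from compound 3 to compound 4 (0.09 log units; within the scatter) is judged to lie within the scatter. Compound 4 is therefore estimated at 3500 nM, with a range from 1500 nM to 8000 nM.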

Compound 4, half-maximal inhibitory concentration: 3370 nM
Compound 4: middle estimate off by 1.0-fold (0.02 log units), on the high side; the measured number falls inside the stated range.
By their numbers in this assay, from the lowest: compounds 2, 4, 3 and 1 (each within the scatter of the next, the first and the last beyond it).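

In this assay, the 2,4-dimethylphenyl and 4-ethylphenyl groups have the same atoms joined differently, and at this place, meta to a large group and opposite the ring nitrogen, exchanging one for the other gives a 1.3-fold lower number from compound 3 to compound 4 (0.11 log units; within the scatter). The ethyl group also fails to separate the new compound from the parent, with a 1.5-fold lower number from compound 1 to compound 4 (0.17 log units; within the scatter), or from the 3-methylphenyl compound, with a 1.9-fold higher number from compound 2 to compound 4 (0.28 log units; within the scatter), so the new value sits within the scatter of all three earlier compounds, even though the 3-methylphenyl compound and the parent remain apart from each other. No measurement of any other kind is available to explain these numbers, so the account of this position stops at the cell read-out.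

The compounds shown carry only hydrocarbon groups on the phenyl ring, so it remains open how this read-out would respond to an amine, a carboxylic acid or a chain longer than ethyl there. On these data alone, it also remains open whether the separation of the 3-methylphenyl compound from the parent reflects a specific preference at this place, since the 4-ethylphenyl compound separates from neither.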